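From cyano to fluoro on the methylated compound

A few compounds are considered here, and "the series" means these few. Any claim that something is new, unique, unknown or untested is made for them only; others in the source may bear on it.

In an ADME assay on CHO cells (Cricetulus griseus) for inhibition, read by MTT assay (a higher number here means a weaker inhibitor, a lower number a stronger inhibitor), compound 1 `CCN(CC)Cc1cccc(Nc2nc3ccccc3n2Cc2ccc(C#N)cc2)c1O` gives > 50000 nM, which is a limit and not a number. Compound 2 `CCN(CC)Cc1cccc(Nc2nc3ccccc3n2Cc2ccc(F)cc2)c1O` gives > 50000 nM, which is also only a limit. Among the compounds with values here, compound 3 `CCN(CC)Cc1cc(C)cc(Nc2nc3ccccc3n2Cc2ccc(C#N)cc2)c1O` gives 14200 nM, the only true number so far and therefore the only firm starting point.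

Compound 4 `CCN(CC)Cc1cc(C)cc(Nc2nc3ccccc3n2Cc2ccc(F)cc2)c1O` differs from compound 3 in a single place: fluoro in place of cyano on an aromatic carbon. This same swap of cyano for fluoro has been measured once, as a step that the two limits leave unreadable from compound 1 to compound 2, so it offers neither a size nor a direction. The other measured change, methyl in place of hydrogen on an aromatic carbon, gave an at least 3.5-fold lower number from compound 1 to compound 3 (0.54 log units; beyond the scatter), and compound 4 keeps that methyl.

With no readable evidence on the swap itself, no change beyond the scatter is expected in this assay. The expected change is a 1.1-fold higher number from compound 3 to compound 4 (0.05 log units; within the scatter). Compound 4 is estimated at 16000 nM, with an expected range of 7000 nM to 40000 nM.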

Compound 4, half-maximal inhibitory concentration: 18700 nM
The estimate for compound 4 lay 1.2-fold (0.07 log units) below the measured number; the measured number falls inside the stated range.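

In this assay, within the data shown here, the swap of cyano for fluoro at this position, on an aromatic carbon para to a large group, can now be read for the first time, and it comes to a 1.3-fold higher number from compound 3 to compound 4 (0.12 log units; within the scatter) with the methyl in place, so 4-cyanobenzyl and 4-fluorobenzyl cannot be told apart on this core. The methyl step can now also be read with fluoro in place of cyano, where it gives an at least 2.6-fold lower number from compound 2 to compound 4 (0.42 log units; beyond the scatter) and so points the same way as it did with cyano. The two steps can be set side by side, but their sizes cannot be compared: the same change on two cores in this assay, an at least 3.5-fold lower number (0.54 log units; beyond the scatter) from compound 1 to compound 3 and an at least 2.6-fold lower number (0.42 log units; beyond the scatter) from compound 2 to compound 4; the limit leaves it open whether they differ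

The same swap on the compounds without the methyl cannot be read: the limit of > 50000 nM in this assay, at which 2 of the 4 values shown sit.

Going by these compounds, whether an amine or a carboxylic acid at this position would move the number beyond the scatter remains open.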